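Swapping the Dichlorobenzyl of Compound 1 for Fluorobenzyl

The source may report more compounds than this note shows. Statements on the series, on what has been measured and on what is new or still open speak of the compounds shown alone.

Within the data shown here, compound 1 `Nc1cc(N)c2nc(-c3ccccc3)c(NCc3ccc(Cl)c(Cl)c3)nc2c1` is tested in a functional assay on SF-539 cells (Homo sapiens) for inhibition, read by sulforhodamine B assay, with a stated time of 48 h (a higher number here means that more compound is tolerated, a lower number that less compound is tolerated), where compound 1 gives 83200 nM, the highest of the two numbers known so far. Compound 2 `COc1cc(CNc2nc3cc(N)cc(N)c3nc2-c2ccccc2)cc(OC)c1OC` gives 26900 nM in this assay, a number beyond the scatter below that of compound 1. Compound 3 `CCOC(=O)[C@H](CCC(=O)O)NC(=O)c1ccc(Oc2nc3cc(N)cc(N)c3nc2-c2ccccc2)cc1` reaches only a limit of this assay, < 100000 nM; this is the limit of < 100000 nM in this assay, at which 1 of the 3 values shown sits. Compound 4 `Nc1cc(N)c2nc(-c3ccccc3)c(NCc3ccc(F)cc3)nc2c1` has not yet been measured. It differs from compound 1 by 4-fluorophenyl in place of 3,4-dichlorophenyl on a saturated chain carbon bound to a nitrogen on an aromatic ring. Among the measured compounds shown here, no measured pair shows a change of this kind, so its size is open; a small step is expected, likely within the scatter, if anything toward a higher number. For compound 4 the expected value is 90000 nM, between 40000 nM and 150000 nM. The expected step is a 1.1-fold higher number from compound 1 to compound 4 (0.03 log units; within the scatter).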

Compound 4, concentration lethal to 50% of the cells: 6920 nM
Compound 4: middle estimate off by 13-fold (1.11 log units), on the high side; the measured number lies below the stated range.
By their numbers in this assay, from the lowest: compound 4; then compound 2; then compound 1.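

On the saturated chain carbon bound to a nitrogen on an aromatic ring, the substituents on the phenyl group matter: in this assay, 4-fluorophenyl in place of 3,4-dichlorophenyl gives a 12-fold lower number from compound 1 to compound 4 (1.08 log units; beyond the scatter). Among these compounds, this is the first readable step at this position, and here less compound is tolerated with 4-fluorobenzyl than with 3,4-dichlorobenzyl. Nothing measured here bears on the cause of this step. The compounds shown leave open whether the step follows the fluorine or the loss of chlorine. A 4-chlorophenyl or an unsubstituted phenyl group on that carbon would separate the two.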